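A few compounds are considered here, and "the series" means these few. Any claim that something is new, unique, unknown or untested is made for them only; others in the source may bear on it.

Compound 1 `Cc1ccc(C2ON=C(c3ccccc3Cl)O2)cc1` gives in an ADME assay on HEK293 cells (Homo sapiens) for cytotoxicity, read by MTT assay, with a stated time of 44 h (a lower number here means a stronger inhibitor, a higher number a weaker inhibitor), a value that is a limit of the assay, > 100000 nM. Compound 2 `Clc1cccc(C2=NOC(c3ccc(Cl)c(Cl)c3)O2)c1` gives in this assay likewise a limit, > 100000 nM. Compound 3 `Clc1ccc(C2ON=C(c3cccc(Cl)c3)O2)cc1` gives in this assay again a limit, > 100000 nM.

Compound 2 thus stands at a limit and not at a number, and the two other values shown are limits too. Going by the values given here, the only step among the measured compounds that bears on the change at hand is the one from compound 2 to compound 3 a step that the two limits leave unreadable from compound 2 to compound 3, and it cannot be read because both ends sit at the limit (the limit of > 100000 nM in this assay, at which 3 of the 3 values shown sit).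

Compound 4 `Clc1cccc(C2=NOC(c3cccc(Cl)c3)O2)c1` differs from compound 2 by hydrogen in place of chloro on an aromatic carbon. Among the compounds with values here, since the one comparable step is unreadable, the size of the step from compound 2 to compound 4 in this assay cannot be taken from the measured pairs, and nothing among the measured compounds points to a reading away from the limit. Compound 4 is therefore expected to give 150000 nM, with a range from 40000 nM to 600000 nM, meaning an expected step that the limit leaves unreadable from compound 2 to compound 4, most likely reported as a limit again.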

Compound 4, half-maximal inhibitory concentration: > 100000 nM
Compound 4 gave a limit, no number; the forecaster's own chance of this, stated with the estimate: 85%; the middle value lies beyond the limit too.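

No new step can be read from compound 4: like compound 2, it stands at a limit and not at a number in this assay, so the step between them stays unreadable: the limit of > 100000 nM in this assay, at which 4 of the 4 values shown sit. The compounds shown leave open whether hydrogen in place of chloro on an aromatic carbon changes the read-out at all.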